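Swapping a side chain on a nucleoside sulfamide

The source may report more compounds than this note shows. Statements on the series, on what has been measured and on what is new or still open speak of the compounds shown alone.

Measured compounds in a functional assay on PBMC cells (Homo sapiens) for inhibition; a higher number here means a weaker inhibitor, a lower number a stronger inhibitor:
compound 1 `CSCC[C@H](N)C(=O)NS(=O)(=O)OC[C@H]1OC[C@@H](n2cnc3c(N)ncnc32)[C@H](O)[C@@H]1O` gives 5200 nM
compound 2 `CC(C)[C@H](N)C(=O)NS(=O)(=O)OC[C@H]1O[C@@H](n2cnc3c(N)ncnc32)[C@H](O)[C@@H]1O` gives 5600 nM
compound 3 `C[C@H](N)C(=O)NS(=O)(=O)OC[C@H]1OC[C@@H](n2cnc3c(N)ncnc32)C[C@@H]1O` gives 5500 nM

Compound 2 gives the highest of the three numbers, yet its nearest neighbour, compound 3, and its furthest, compound 1, both lie within the scatter of it, so the three compounds cannot be told apart on these values. Compound 4 `CSCC[C@H](N)C(=O)NS(=O)(=O)OC[C@H]1O[C@@H](n2cnc3c(N)ncnc32)[C@H](O)[C@@H]1O` is not yet measured. It differs from compound 2 in one place: 2-(methylsulfanyl)ethyl in place of isopropyl on a saturated chain carbon bound to an amine nitrogen and a carbonyl carbon. Going by the values given here, no measured pair shows this change alone. The expected step of a 1.0-fold lower number from compound 2 to compound 4 (0.02 log units; within the scatter) in this assay is none beyond the scatter, because compound 1 carrying the same 2-(methylsulfanyl)ethyl group gives 5200 nM. Compound 4 is therefore estimated at 5400 nM, within 2500 nM to 11000 nM.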

Compound 4, half-maximal inhibitory concentration: 500 nM
Beside the measured number, compound 4's estimate is 11-fold (1.03 log units) above it; the whole stated range lies above it.
By their numbers in this assay, from the lowest: compound 4; then compounds 1, 3 and 2 (each within the scatter of the next).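

In this assay, an 11-fold lower number from compound 2 to compound 4 (1.05 log units; beyond the scatter) shows that this position, on a saturated chain carbon bound to an amine nitrogen and a carbonyl carbon, responds strongly when 2-(methylsulfanyl)ethyl replaces isopropyl. The group does not bring this low number on every core, since compound 1 gives 5200 nM with the same group on its different core. Nothing measured here explains the step.

Still open, from the compounds shown here alone, is how a longer chain, a carboxylic acid or an amine at this position would compare with 2-(methylsulfanyl)ethyl on the core of compound 4.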